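The source may hold more compounds than are shown below. What is called first, only, known or untested is meant among the compounds shown, and "the series" means these compounds.

Measured so far in a functional assay on SK-OV-3 cells (Homo sapiens) for cytotoxicity, read by MTT assay, with a stated time of 24 h; on this read-out higher numbers stand for weaker inhibition and lower numbers for stronger inhibition:
Compound 1 `O=Cc1cc2ccccc2n(Cc2ccccc2)c1=O`: > 100000 nM (a limit of the assay, not a number)
Compound 2 `C#CCn1c(=O)c(/C=C/C(=O)/C=C(O)/C=C/c2ccc(O)c(OC)c2)cc2ccccc21`: 19000 nM
Compound 3 `C#CCn1c(=O)c(/C=C/C(=O)/C=C(O)/C=C/c2ccc(O)c(OC)c2)cc2cc(OC)ccc21`: 14000 nM

For the measured compounds named here, compound 2 and compound 3 give the only two true numbers in this assay, and these two lie within the scatter of each other. Compound 3 therefore stands level with compound 2 on the data shown.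

Compound 4 `C#CCn1c(=O)c(/C=C/C(=O)/C=C(O)/C=C/c2ccc(O)c(OC)c2)cc2cc(C)ccc21` has not yet been measured. Its difference from compound 3 is methyl in place of methoxy on an aromatic carbon. Put simply, it has methyl in place of methoxy on an aromatic carbon.

Going by the values given here, one measured step bears on this change: a 1.4-fold lower number from compound 2 to compound 3 (0.13 log units; within the scatter), with methoxy in place of hydrogen. Since that step stayed within the scatter, the swap to methyl is expected to cause no change in this assay beyond the scatter. The expected outcome is a 1.1-fold higher number from compound 3 to compound 4 (0.03 log units; within the scatter). The estimate for compound 4 is 15000 nM, with an expected range from 7000 nM to 32000 nM.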

Compound 4, half-maximal inhibitory concentration: 12800 nM
The estimate for compound 4 lay 1.2-fold (0.07 log units) above the measured number; the range from low to high includes it.
By their numbers in this assay, from the lowest: compounds 4, 3 and 2 (each within the scatter of the next). At a limit, above all of these: compound 1.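

In this assay, this position on the ring has now carried hydrogen, methoxy and methyl, and all three compounds lie within the scatter of one another. Methyl in place of methoxy gives a 1.1-fold lower number from compound 3 to compound 4 (0.04 log units; within the scatter), and methyl in place of hydrogen gives a 1.5-fold lower number from compound 2 to compound 4 (0.17 log units; within the scatter), so neither swap moves the number measurably. Losing the oxygen, and with it the one hydrogen-bond acceptor of methoxy, therefore leaves no visible mark in this read-out, and nothing measured here explains why the three compounds stay level.

Going by these compounds, whether an amine, a carboxylic acid or a longer chain at this position would move the number beyond the scatter stays open. Also open, on these data alone, is whether this flat result would hold in other cell types.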